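A few compounds are considered here, and "the series" means these few. Any claim that something is new, unique, unknown or untested is made for them only; others in the source may bear on it.

In a functional assay on KB cells (Homo sapiens) for inhibition (a higher number here means a weaker inhibitor, a lower number a stronger inhibitor), compound 1 `Clc1cc2nc(Cl)n(Cc3ccccc3)c2cc1Cl` gives > 100000 nM as a limit of the assay and not a number. Compound 2 `Clc1ccc(Cn2c(Cl)nc3cc(Cl)c(Cl)cc32)cc1` gives > 100000 nM and that too is only a limit. Compound 3 `Cc1ccc(Cn2c(Cl)nc3cc(Cl)c(Cl)cc32)cc1` gives > 100000 nM and so also stands at a limit, with no exact number of its own. The record so far is therefore the limit of > 100000 nM in this assay, at which 3 of the 3 values shown sit, and no exact figure.

Compound 4 `Fc1ccc(Cn2c(Cl)nc3cc(Cl)c(Cl)cc32)cc1` differs from compound 3 by a single swap, fluoro in place of methyl on an aromatic carbon gives the count. For the measured compounds named here, three measured steps bear on this swap, namely a step that the two limits leave unreadable from compound 1 to compound 2 and a step that the two limits leave unreadable from compound 1 to compound 3 and also a step that the two limits leave unreadable from compound 2 to compound 3 as the last of them. None of these has a readable size, so they point in no direction, and no step beyond the usual scatter is expected. The expected move is a number no higher from compound 3 to compound 4 (the limit leaves the size open) as an estimate only. For compound 4 the estimate is 100000 nM with an expected range from 40000 nM to 200000 nM and a limit of the assay is the likeliest outcome.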

Compound 4, half-maximal inhibitory concentration: > 100000 nM
Compound 4 ended at the assay's limit (the forecaster's own chance of this, stated with the estimate: 85%); the middle value sits exactly at the limit.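

The steps linking compound 4 to compound 1, compound 2 and compound 3 cannot be read, since each pair ends at a limit and not a number: the limit of > 100000 nM in this assay, at which 4 of the 4 values shown sit.

The compounds shown leave open how strongly any of them inhibits, and whether the group swapped on the six-membered aromatic ring changes inhibition at all.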